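A few compounds are considered here, and "the series" means these few. Any claim that something is new, unique, unknown or untested is made for them only; others in the source may bear on it.

Compound 1 `C=CC[C@@H]1C[C@@H](c2ccc(Cl)c(Cl)c2)[C@H](NC(=O)c2cc(-c3c(Cl)cnn3C)c(Cl)o2)CN1`: in an assay for inhibition of RAC-alpha serine/threonine-protein kinase (Homo sapiens), read by HTRF, with a stated time of 1 h (a higher number here means a weaker inhibitor, a lower number a stronger inhibitor), compound 1 gives 12.4 nM.
Compound 2 `Cn1ncc(Cl)c1-c1cc(C(=O)N[C@@H]2CN[C@H](CC(=O)NC3CC3)C[C@H]2c2ccc(Cl)c(Cl)c2)oc1Cl`: in this assay compound 2 gives 3.95 nM.

Compound 2 stands lowest of these two numbers. For the measured compounds named here, the only measured step, a 3.1-fold lower number from compound 1 to compound 2 (0.50 log units; beyond the scatter), lies beyond the scatter and separates the pair.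

Compound 3 `Cn1ncc(Cl)c1-c1cc(C(=O)N[C@@H]2CN[C@H](CCN3CCCC3)C[C@H]2c2ccc(Cl)c(Cl)c2)oc1Cl` differs from compound 2 by (pyrrolidin-1-yl)methyl in place of cyclopropylcarbamoyl on a saturated chain carbon bound to a saturated ring carbon. Going by the values given here, no measured step swaps one of these two groups for the other, and the single step known concerns a different exchange, so it gives no direction here. The expected change is therefore none beyond the scatter, a 1.3-fold higher number from compound 2 to compound 3 (0.10 log units; within the scatter). Compound 3 is estimated at 5 nM, within 1.5 nM to 16 nM.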

Compound 3, half-maximal inhibitory concentration: 6.41 nM
Beside the measured number, compound 3's estimate is 1.3-fold (0.11 log units) below it; the measured number falls inside the stated range.
By their numbers in this assay, from the lowest: compounds 2, 3 and 1 (each within the scatter of the next, the first and the last beyond it).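

Replacing cyclopropylcarbamoyl with (pyrrolidin-1-yl)methyl on a saturated chain carbon bound to a saturated ring carbon gives a 1.6-fold higher number from compound 2 to compound 3 (0.21 log units; within the scatter) in this assay, so the hydrogen-bond donor of the leaving group is not needed here to keep the number at this level. Replacing vinyl with the same group gives a 1.9-fold lower number from compound 1 to compound 3 (0.29 log units; within the scatter), so the new group is separated from neither earlier one. No supporting measurement explains these results.

Still open, from the compounds shown here alone, is how a carboxylic acid at this place would read. A longer chain ending in a pyrrolidine also remains untested among the compounds shown.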